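Extending a Propyl Chain to Pentyl

This account rests on a few compounds, and the source may have more. Where it says the series, first, only, none or still open, it means among the compounds named here.

In a functional assay on PC-3 cells (Homo sapiens) for cytotoxicity, read by MTT assay, with a stated time of 72 h (a lower number here means a stronger inhibitor, a higher number a weaker inhibitor), compound 1 `COc1ccc(COCNc2n[n+]([O-])c3ccccc3[n+]2[O-])cc1` gives 14500 nM. Compound 2 `CCCOCNc1n[n+]([O-])c2ccccc2[n+]1[O-]` gives 14200 nM, which puts the two level within the usual scatter of repeat measurements. Compound 3 `CCCCCOCNc1n[n+]([O-])c2ccccc2[n+]1[O-]` keeps the same core and changes only the chain of compound 2: ethyl in place of hydrogen on a saturated chain carbon, three bonds along the chain from an oxygen on a saturated carbon. In words, ethyl takes the place of hydrogen on a saturated chain carbon, three bonds along the chain from an oxygen on a saturated carbon, so propyl becomes pentyl. Among the compounds with values here, only one measured step bears on this: a 1.0-fold lower number from compound 1 to compound 2 (0.01 log units; within the scatter). That step swapped 4-methoxyphenyl for ethyl, and it is thin evidence, but it gives no sign of sensitivity to this part of the molecule. No step beyond the scatter is therefore expected in this assay. The expected step is a 1.1-fold lower number from compound 2 to compound 3 (0.06 log units; within the scatter). For compound 3 the estimate is 12500 nM, with an expected range of 6500 nM to 23000 nM.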

Compound 3, half-maximal inhibitory concentration: 9200 nM
For compound 3 the middle estimate is 1.4-fold (0.13 log units) above the measured one; the range from low to high includes it.
By their numbers in this assay, from the lowest: compounds 3, 2 and 1 (each within the scatter of the next).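

Going from propyl to pentyl gives a 1.5-fold lower number from compound 2 to compound 3 (0.19 log units; within the scatter) in this assay, the first test of adding to this chain without replacing its end. Measured against the aromatic end of compound 1, the same pentyl chain gives a 1.6-fold lower number from compound 1 to compound 3 (0.20 log units; within the scatter), so neither an added ethyl nor a swap of 4-methoxyphenyl for butyl moves the number beyond the scatter in these three compounds. No measurement shown here offers an explanation for these small differences.

The compounds shown leave open whether a chain longer than pentyl would produce a step beyond the scatter. They also leave open what an amine or a carboxylic acid at the end of the chain would do to the reading in this cell assay.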